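One Hydroxy Group Fewer on a Compound at the Limit

The source may report more compounds than this note shows. Statements on the series, on what has been measured and on what is new or still open speak of the compounds shown alone.

Compound 1 `O=C(Nc1ccc(Sc2nc3ccccc3s2)cc1)c1cc(Br)cc(Br)c1O`: in an assay on isolated protein for inhibition of thiosulfate sulfurtransferase (Homo sapiens), with a stated time of 60 min, in the absence of a further agent (a higher number here means a weaker inhibitor, a lower number a stronger inhibitor), compound 1 gives only a limit of the assay, > 100000 nM.
Compound 2 `O=C(Nc1ccc(Sc2nc3ccccc3s2)c(Cl)c1)c1cccc(Br)c1O`: in this assay compound 2 likewise gives only a limit, > 100000 nM.
Compound 3 `COc1c(Br)cccc1C(=O)Nc1cccc(Cl)c1`: in this assay compound 3 also gives only a limit, > 100000 nM.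

Compound 1 therefore cannot be ranked among the numbers shown: its value is a limit, and the other two values are limits as well, which is what the limit of > 100000 nM in this assay, at which 3 of the 3 values shown sit, records. Among the compounds with values here, no step between measured compounds can be drawn from these data, and no pair of them differs in a single place.

Compound 4 `O=C(Nc1ccc(Sc2nc3ccccc3s2)cc1)c1cc(Br)cc(Br)c1` differs from compound 1 in one place, (hydrogen in place of hydroxy on an aromatic carbon). Within the data shown here, with compound 1 sitting at the limit, there is no measured step on which to build, and the account expects no step in this assay beyond the scatter in either direction; most likely compound 4 will again return only a limit. The estimate for compound 4 is 150000 nM, expected to lie between 50000 nM and 500000 nM. That estimate means an expected step that the limit leaves unreadable from compound 1 to compound 4.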

Compound 4, half-maximal inhibitory concentration: > 100000 nM
Compound 4: only a limit was reported; the forecaster's own chance of this, stated with the estimate: 85%; the middle value lies beyond the limit too.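

In this assay compound 4 also gives only a limit (> 100000 nM). No step from compound 1 to compound 4 can be read, because both compounds sit at the same limit: the limit of > 100000 nM in this assay, at which 4 of the 4 values shown sit.

The compounds shown leave open whether hydrogen in place of hydroxy changes inhibition at all, and what structure would give a value short of the limit.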